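Nitro in place of fluoro in compound 1

The source may report more compounds than this note shows. Statements on the series, on what has been measured and on what is new or still open speak of the compounds shown alone.

Compound 1 `CC(=NNC(=S)Nc1ccccc1F)c1ccccn1`: 0.39 nM
Compound 2 `C/C(=N/NC(=S)Nc1ccccc1F)c1ccccn1`: 0.39 nM

Both values come from a functional assay on MCF7 cells (Homo sapiens) for cytotoxicity, read by MTT assay, with a stated time of 48 h (on this read-out lower numbers stand for stronger inhibition and higher numbers for weaker inhibition), where compound 1 stands level with compound 2. Within the data shown here, the only measured step, no change at the digits printed from compound 1 to compound 2 (within the scatter), concerns (the fact that one of compounds 1 and 2 is drawn with a defined configuration and the other without, at the place where they differ), so it does not bear on the substituent. Compound 3 `CC(=NNC(=S)Nc1ccccc1[N+](=O)[O-])c1ccccn1` carries nitro in place of fluoro on an aromatic carbon. Among the measured compounds shown here, no measured step covers that change. Since compound 1 already reads 0.39 nM, a modest weakening is expected rather than a gain. The estimated change is a 2.1-fold higher number from compound 1 to compound 3 (0.31 log units; beyond the scatter). For compound 3 the expected value is 0.8 nM, with an estimated range of 0.15 nM to 5 nM.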

Compound 3, half-maximal inhibitory concentration: 5.7 nM
The estimate for compound 3 lay 7.1-fold (0.85 log units) below the measured number; the whole stated range lies below it.
By their numbers in this assay, from the lowest: compounds 1 and 2 (each within the scatter of the next); then compound 3.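

In this assay, among these compounds, this place on an aromatic carbon, ortho to a large group, proves sensitive to its substituent: nitro in place of fluoro gives a 15-fold higher number from compound 1 to compound 3 (1.16 log units; beyond the scatter) and is the first measured change of substituent here. Fluoro therefore cannot be exchanged for nitro at this place without a large loss. Nothing measured in this series accounts for that step. On these data alone, whether the loss is specific to nitro remains open, since an amine, a methoxy group or plain hydrogen at this place could read quite differently.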